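The source may hold more compounds than are shown below. What is called first, only, known or untested is meant among the compounds shown, and "the series" means these compounds.

Among the measured compounds shown here, in an ADME assay on cells (Homo sapiens) for cytotoxicity, read by polymerase chain reaction, with a stated time of 3 days (a lower number here means that less compound is tolerated, a higher number that more compound is tolerated), compound 2, `Cc1nc(NC(C)C)nc(N[C@@H]2C[C@H](CO)[C@@H](O)[C@H]2O)c1-c1nc2ccccc2s1`, gives 13000 nM, the only plain number among the two compounds measured. Compound 1, `Nc1nc(Cl)c(-c2ncco2)c(N[C@@H]2C[C@H](CO)[C@@H](O)[C@H]2O)n1`, reaches only the limit of the assay at > 25000 nM. Its position is described by the limit of > 25000 nM in this assay, at which 1 of the 2 values shown sits. Compound 3, `Cc1nc(Nc2ncco2)nc(N[C@@H]2C[C@H](CO)[C@@H](O)[C@H]2O)c1-c1nc2ccccc2s1`, has not yet been measured in this assay; it carries 1,3-oxazol-2-yl in place of isopropyl on a nitrogen on an aromatic ring. For the measured compounds named here, no measured pair maps this change, so a step not beyond the usual scatter is expected, in either direction. Compound 3 is accordingly expected to give 15000 nM, with a range from 6000 nM to 30000 nM. That estimate means an expected step of a 1.2-fold higher number from compound 2 to compound 3 (0.06 log units; within the scatter).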

Compound 3, half-maximal cytotoxic concentration: > 25000 nM
Compound 3 ended at the assay's limit (the forecaster's own chance of this, stated with the estimate: 30%); middle value at least 1.6-fold (0.22 log units) from the limit.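

In this assay, among the compounds shown here, the swap on a nitrogen on an aromatic ring gives the first measured step at this position: an at least 1.9-fold higher number from compound 2 to compound 3 (0.28 log units; that floor lies within the scatter). This step is only a floor, and its true size cannot be read. Compound 3 joins compound 1 at the limit: the limit of > 25000 nM in this assay, at which 2 of the 3 values shown sit.

The compounds shown leave open how far past the limit compound 3 lies. They also leave open whether a phenyl ring or a longer alkyl chain on this nitrogen would give a number that can be read.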